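Pyridinylmethylamino Arm in Place of a Phenylethylamino Arm

A few compounds are considered here, and "the series" means these few. Any claim that something is new, unique, unknown or untested is made for them only; others in the source may bear on it.

Measured compounds:
compound 1 `c1cc(CNC2CCN(CCCc3c[nH]c4ccc(-n5cnnc5)cc34)CC2)co1` — 78 nM
compound 2 `CN(Cc1ccsc1)C1CCN(CCCc2c[nH]c3ccc(-n4cnnc4)cc23)CC1` — 35 nM
compound 3 `C[C@H](NCC1CCN(CCCc2c[nH]c3ccc(-n4cnnc4)cc23)CC1)c1ccccc1` — 58 nM

The three compounds share one core and differ only in the group on a saturated ring carbon. In an assay on CHO cells for displacement of a labelled ligand from 5-hydroxytryptamine receptor 1B (Homo sapiens) (a lower number here means a stronger inhibitor, a higher number a weaker inhibitor), compound 1 gives 78 nM, compound 2 gives 35 nM and compound 3 gives 58 nM. Compound 3 stands second highest of the three numbers. The steps of a 1.3-fold lower number from compound 1 to compound 3 (0.13 log units; within the scatter) and a 1.7-fold higher number from compound 2 to compound 3 (0.22 log units; within the scatter) lie within the scatter; only a 2.2-fold lower number from compound 1 to compound 2 (0.35 log units; beyond the scatter) goes beyond it, and that one is modest.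

Compound 4 `c1cncc(CNC2CCN(CCCc3c[nH]c4ccc(-n5cnnc5)cc34)CC2)c1` carries the change (((pyridin-3-yl)methyl)amino in place of ((1-phenylethyl)amino)methyl on a saturated ring carbon). The steps of a 1.3-fold lower number from compound 1 to compound 3 (0.13 log units; within the scatter) and a 1.7-fold higher number from compound 2 to compound 3 (0.22 log units; within the scatter) bear on this change, since each also swaps the whole arm on that carbon, and both were small. Nothing among the three measured compounds points to a large move in this assay for such a swap.

Compound 4 is therefore expected to give about 65 nM, with a range from 25 nM to 170 nM. That estimate means a step of a 1.1-fold higher number from compound 3 to compound 4 (0.05 log units; within the scatter), expected to stay within the scatter.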

Compound 4, half-maximal inhibitory concentration: 140 nM
Compound 4: middle estimate off by 2.2-fold (0.33 log units), on the low side, within the range that was stated.
By their numbers in this assay, from the lowest: compounds 2, 3, 1 and 4 (each within the scatter of the next, the first and the last beyond it).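

In this assay, a swap of the whole arm on the saturated ring carbon can move the number beyond the scatter, as the modest steps (a 2.4-fold higher number from compound 3 to compound 4 (0.38 log units; beyond the scatter)) and (a 4.0-fold higher number from compound 2 to compound 4 (0.60 log units; beyond the scatter)) show, whereas the earlier swaps to compound 3 stayed within it. The narrower change of pyridin-3-yl in place of furan-3-yl, with the rest of the arm kept, stays within the scatter (a 1.8-fold higher number from compound 1 to compound 4 (0.25 log units; within the scatter)), so these two rings are not told apart here. Nothing shown explains these differences.

The compounds shown leave open whether a pyridin-4-yl or plain phenyl ring on the same arm would also stay within the scatter of compound 1. They also leave open what a methyl on the amine nitrogen alone contributes, as compound 2 changes both that methyl and the ring.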